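The compounds below may be only part of what the source reports. "The series", "measured", "known", "first", "only" and "open" are said of these compounds alone.

In a functional assay on KB 3-1 cells (Homo sapiens) for inhibition, with a stated time of 72 h (on this read-out lower numbers stand for stronger inhibition and higher numbers for weaker inhibition), the measured compounds give:
Compound 1 `CC(=O)Oc1c(O)cc2oc(-c3ccccc3)cc(=O)c2c1O` gives 61600 nM
Compound 2 `CC(=O)Oc1cc2oc(-c3ccccc3)cc(=O)c2c(OC(C)=O)c1OC(C)=O` gives 57200 nM
Compound 3 `COc1cc2oc(-c3ccccc3)cc(=O)c2c(OC)c1OC(C)=O` gives > 100000 nM as a limit of the assay

Compound 1 lies within the usual scatter of compound 2, so these two values cannot be told apart. Compound 3 offers a limit and no number to compare.

Compound 4 `O=c1cc(-c2ccccc2)oc2cc(O)c(OCc3ccccc3)c(O)c12` has benzyl in place of acetyl on an oxygen on an aromatic ring and is still unmeasured. For the measured compounds named here, no measured pair shows this change alone, so any expectation is rough and rests on compound 1 at 61600 nM as the starting point. In this assay the estimated 1.8-fold lower number from compound 1 to compound 4 (0.25 log units; within the scatter) is expected to be about the size of the scatter, leaning toward stronger inhibition. Compound 4 is expected at 35000 nM with an estimated range from 10000 nM to 100000 nM as its likely span.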

Compound 4, half-maximal inhibitory concentration: 3200 nM
Compound 4: middle estimate off by 11-fold (1.04 log units), on the high side, outside the stated range (below it).
By their numbers in this assay, from the lowest: compound 4; then compounds 2 and 1 (each within the scatter of the next). At a limit, above all of these: compound 3.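

In this assay putting benzyl in place of acetyl on this oxygen on an aromatic ring gives a 19-fold lower number from compound 1 to compound 4 (1.28 log units; beyond the scatter) and so shows that the group at this place can strongly change inhibition. The earlier compounds shown here offered no pair differing in one place, so they could not show this. Nothing among the data shown explains why this change has so large an effect.

Going by these compounds, whether the aromatic ring of benzyl is itself needed stays open. A longer chain without a ring, or a chain carrying an amine, on this oxygen would help to answer that.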